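The source may hold more compounds than are shown below. What is called first, only, known or untested is meant among the compounds shown, and "the series" means these compounds.

Measured compounds in a functional assay on PC-3 cells (Homo sapiens) for cytotoxicity, read by MTT assay, with a stated time of 72 h; a lower number here means a stronger inhibitor, a higher number a weaker inhibitor:
compound 1, `CC1=C(/C=C/C(=O)/C=C/c2cccc(C(F)(F)F)c2)C(C)(C)CCC1O`, gives 3500 nM
compound 2, `CC1=C(/C=C/C(=O)/C=C/c2cccc(C)c2)C(C)(C)CCC1O`, gives 6200 nM
compound 3, `COc1cccc(/C=C/C(=O)/C=C/C2=C(C)C(O)CCC2(C)C)c1`, gives 6500 nM

Compound 3 carries the highest of the three numbers, but a 1.0-fold higher number from compound 2 to compound 3 (0.02 log units; within the scatter) and a 1.9-fold higher number from compound 1 to compound 3 (0.27 log units; within the scatter) both lie within the scatter, so the three compounds are not separated in this assay; likewise a 1.8-fold higher number from compound 1 to compound 2 (0.25 log units; within the scatter).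

Compound 4, `CCOC(OCC)c1cccc(/C=C/C(=O)/C=C/C2=C(C)C(O)CCC2(C)C)c1`, follows from compound 3 by diethoxymethyl in place of methoxy on an aromatic carbon. Among the compounds with values here, the steps that bear on this change are the three swaps at the same aromatic carbon: trifluoromethyl to methyl, trifluoromethyl to methoxy and methyl to methoxy, each of which stayed within the scatter. Diethoxymethyl has not been tried in the series, and it is a larger group than any of the three measured ones, so no direct precedent exists; what the measured steps show is that exchanging the group at this position has so far not moved the number beyond the scatter. The expectation for compound 4 in this assay is therefore no step beyond the scatter, in either direction, with a wider range than usual to allow for the untested group.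

Compound 4 is estimated at 6500 nM, with a range from 2800 nM to 15000 nM, which means an expected step of no change at the digits printed from compound 3 to compound 4 (within the scatter).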

Compound 4, half-maximal inhibitory concentration: 4700 nM
The estimate for compound 4 lay 1.4-fold (0.14 log units) above the measured number; measured number inside the range.
By their numbers in this assay, from the lowest: compounds 1, 4, 2 and 3 (each within the scatter of the next).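

In this assay, the aromatic carbon that held trifluoromethyl, methyl and methoxy now also carries diethoxymethyl, with 7 heavy atoms against 2 for methoxy and 2 hydrogen-bond acceptors against 1, and the new group still gives no separation: a 1.4-fold lower number from compound 3 to compound 4 (0.14 log units; within the scatter), a 1.3-fold lower number from compound 2 to compound 4 (0.12 log units; within the scatter) and a 1.3-fold higher number from compound 1 to compound 4 (0.13 log units; within the scatter). The earlier compounds showed this flat picture only among three groups that were compact beside diethoxymethyl; it now holds across all four compounds shown, so no order among these groups can be read and the change of group at this carbon has yet to give a step beyond the scatter. No measurement at hand bears on why the four numbers stay together.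

All four groups at this carbon lack a hydrogen-bond donor and a net charge, so the compounds shown leave open whether an amine or a carboxylic acid there would give a step beyond the scatter. Also open, from the compounds shown here alone, is whether a group with a ring, such as a morpholine, would leave the number as undisturbed as diethoxymethyl does.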